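Iodo replacing the alkyne on the weakest member

This account rests on a few compounds, and the source may have more. Where it says the series, first, only, none or still open, it means among the compounds named here.

Three members of the series have been measured in a functional assay on 1321N1 cells for antagonist activity at P2Y purinoceptor 6 (Homo sapiens), read by fluorescence and calcium flux; on this read-out lower numbers stand for stronger inhibition and higher numbers for weaker inhibition. Compound 1 `CC(C)(C)OC(=O)NCC#Cc1ccc2c(c1)C=C([N+](=O)[O-])C(C(F)(F)F)O2` gives 1200 nM. Compound 2 `O=C(O)c1ccc(C#Cc2ccc3c(c2)C=C([N+](=O)[O-])C(C(F)(F)F)O3)cc1` gives 1090 nM. Compound 3 `CC(C)(C)C#Cc1ccc2c(c1)C=C([N+](=O)[O-])C(C(F)(F)F)O2` gives 6590 nM, the highest of the three numbers; its nearest neighbour is compound 1, with a 5.5-fold higher number from compound 1 to compound 3 (0.74 log units; beyond the scatter), and the furthest is compound 2, with a 6.0-fold higher number from compound 2 to compound 3 (0.78 log units; beyond the scatter). The step of a 1.1-fold lower number from compound 1 to compound 2 (0.04 log units; within the scatter) shows that the two larger groups on the triple-bonded carbon give numbers indistinguishable from each other.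

Compound 4 `O=[N+]([O-])C1=Cc2cc(I)ccc2OC1C(F)(F)F` differs from compound 3 as follows: iodo in place of 3,3-dimethylbut-1-yn-1-yl on an aromatic carbon. Among the compounds with values here, no measured step removes the triple bond itself; the two steps that reach compound 3, from compound 1 and from compound 2, only exchange the group carried on the triple-bonded carbon, and both are modest in size. They bear on the step to compound 4 only in showing that this part of the core is sensitive to what is placed there, without telling in which direction a loss of the whole 3,3-dimethylbut-1-yn-1-yl group would move the number.

The step to compound 4 is therefore expected to be a 1.5-fold lower number from compound 3 to compound 4 (0.17 log units; within the scatter), with no confident direction. For compound 4 the estimate in this assay is 4500 nM, within a range from 1000 nM to 20000 nM.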

Compound 4, half-maximal inhibitory concentration: 4000 nM
Compound 4: middle estimate off by 1.1-fold (0.05 log units), on the high side; measured number inside the range.
By their numbers in this assay, from the lowest: compounds 2 and 1 (each within the scatter of the next); then compounds 4 and 3 (each within the scatter of the next).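

In this assay, iodo in place of 3,3-dimethylbut-1-yn-1-yl on this aromatic carbon gives a 1.6-fold lower number from compound 3 to compound 4 (0.22 log units; within the scatter), so compound 3 and compound 4 cannot be told apart. The earlier steps shown here only exchanged the group carried on the triple-bonded carbon, whereas this one removes the triple bond as well, and for this pair neither that bond nor the tert-butyl group it carries shows up in the read-out. No measurement available here explains why the two numbers fall so close together.

The compounds shown leave open whether the triple bond matters once the group beyond it is the 4-carboxyphenyl of compound 2 or the ((tert-butoxycarbonyl)amino)methyl of compound 1, a question that a 4-carboxyphenyl group set directly on the aromatic carbon, with no triple bond, would address. They also leave open whether iodo itself contributes to the number in compound 4, which hydrogen, chloro or an amine on the same carbon would test.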